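A Methoxy Ester Variant Tested on Breast Cancer Cells

The source may report more compounds than this note shows. Statements on the series, on what has been measured and on what is new or still open speak of the compounds shown alone.

Compound 1 `Cc1cc2c(C(C)C)ccc(C)c2cc1OC(=O)c1cccc(C(F)(F)F)c1`: 41.5%
Compound 2 `COc1cccc(C(=O)Oc2cc3c(C)ccc(C(C)C)c3cc2C)c1`: 31.8%

Two esters sharing the same core have been tested in a functional assay on MCF7 cells (Homo sapiens) for antiproliferative activity, read by sulforhodamine B assay, with a stated time of 48 h, tested at 50 uM; a lower number here means less inhibition, a higher number more inhibition at the concentration tested (going by the name of the read-out). Compound 1 gives 41.5% in this assay, and compound 2 gives 31.8%. Compound 2 has the lower of the two numbers, but the gap to compound 1 lies within the scatter, so the two cannot be told apart. For the measured compounds named here, the only measured step, a number 9.7 percentage points lower from compound 1 to compound 2 (within the scatter), concerns a methoxy in place of trifluoromethyl on an aromatic carbon and is within the scatter.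

Compound 3 `COc1ccc(C(=O)Oc2cc3c(C)ccc(C(C)C)c3cc2C)cc1` has not yet been measured. It differs from compound 2 as 4-methoxyphenyl in place of 3-methoxyphenyl on a carbonyl carbon. Going by the values given here, no measured step covers this kind of rearrangement of the methoxy-bearing ring, so the expectation rests only on the fact that the one recorded change to this part of the molecule produced no step beyond the scatter. The step of a number 1.2 percentage points higher from compound 2 to compound 3 (within the scatter) is therefore expected to stay within the scatter. For compound 3 the estimated value in this assay is 33%, with a range from 18% to 48%.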

Compound 3, a percentage reported as inhibition, at one concentration (the size of the read-out at that concentration, not a potency): 93.4%
The estimate for compound 3 lay 60.4 percentage points below the measured number; measured number outside the range, above it.
By their numbers in this assay, from the lowest: compounds 2 and 1 (each within the scatter of the next); then compound 3.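

In this assay, 4-methoxyphenyl in place of 3-methoxyphenyl on a carbonyl carbon gives a number 61.6 percentage points higher from compound 2 to compound 3 (beyond the scatter), even though the two compounds contain the same atoms and differ only in how they are joined. The earlier change on this ring, a swap of one group for another, gave a number 9.7 percentage points lower from compound 1 to compound 2 (within the scatter), so it did not show that this part of the molecule could matter; the new step shows that, for this pair, where the methoxy sits on the ring can separate a modest number from a very high one. The data shown offer no measurement that accounts for this jump.

The compounds shown leave open whether the high number belongs to the methoxy group itself, or whether an amine, a carboxylic acid or a longer chain such as ethoxy in its place on the ring of compound 3 would keep it. On these data alone, each number also comes from a single concentration, so how potent compound 3 is and whether its effect extends to other cell lines remain open.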